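The source may hold more compounds than are shown below. What is called first, only, known or untested is meant among the compounds shown, and "the series" means these compounds.

Of the compounds shown here, three built on one shared core have been measured in a functional assay on SW-620 cells (Homo sapiens) for inhibition, read by MTT assay, with a stated time of 72 h; on this read-out lower numbers stand for stronger inhibition and higher numbers for weaker inhibition. Compound 1 `COc1cc(Oc2cccc(Nc3ccccc3)c2)cc(OC)c1CNCc1ccc(Br)cc1` gives 11200 nM in this assay. Compound 2 `COc1cc(Oc2cccc(Nc3ccccc3)c2)cc(OC)c1CNCc1ccc(Cl)cc1` gives 6340 nM in this assay. Compound 3 `COc1cc(Oc2cccc(Nc3ccccc3)c2)cc(OC)c1CNCc1ccccc1` gives 7490 nM in this assay, the second highest of the three numbers; its nearest neighbour is compound 2 and its furthest is compound 1, and both gaps fall within the usual scatter of repeated measurements. Every measured step changes a substituent on an aromatic carbon: a 1.8-fold lower number from compound 1 to compound 2 (0.25 log units; within the scatter), a 1.5-fold lower number from compound 1 to compound 3 (0.17 log units; within the scatter) and a 1.2-fold higher number from compound 2 to compound 3 (0.07 log units; within the scatter), each within the scatter.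

Compound 4 `COc1cc(Oc2cccc(Nc3ccccc3)c2)cc(OC)c1CN[C@H](C)c1ccccc1` differs from compound 3 at a different place: methyl in place of hydrogen on a saturated chain carbon bound to an amine nitrogen and an aromatic carbon. Among the measured compounds shown here, no measured step touches this saturated chain carbon, so the three steps above give no direct guide to the effect of this change. They show only that, across the three compounds made so far, a single small change has not moved the numbers beyond the scatter. On that evidence no step beyond the scatter is expected in this assay. The estimated step from compound 3 to compound 4 is a 1.0-fold higher number from compound 3 to compound 4 (0.00 log units; within the scatter). Compound 4 is expected to give about 7500 nM in this assay, within a range from 3000 nM to 19000 nM.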

Compound 4, half-maximal inhibitory concentration: 18700 nM
Beside the measured number, compound 4's estimate is 2.5-fold (0.40 log units) below it, and the stated range covers the measured number.
By their numbers in this assay, from the lowest: compounds 2, 3, 1 and 4 (each within the scatter of the next, the first and the last beyond it).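

In this assay the added methyl on the saturated chain carbon bound to an amine nitrogen and an aromatic carbon gives a 2.5-fold higher number from compound 3 to compound 4 (0.40 log units; beyond the scatter) and so shows what the changes on the aromatic carbon did not: a single small change can move this series beyond the scatter, here towards weaker inhibition. The comparisons on the amine nitrogen give a mixed picture, with 1-phenylethyl in place of 4-chlorobenzyl giving a 2.9-fold higher number from compound 2 to compound 4 (0.47 log units; beyond the scatter) but 1-phenylethyl in place of 4-bromobenzyl giving a 1.7-fold higher number from compound 1 to compound 4 (0.22 log units; within the scatter) and so leaving compound 4 not separable from compound 1 in this assay. Nothing available explains why adding the methyl is followed by this shift.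

The compounds shown leave open whether an ethyl or a hydroxymethyl on this chain carbon would move the number further, and whether the mirror-image form of the 1-phenylethyl group would give a similar number. They also leave open whether the methyl would have a similar effect with chloro or bromo on the aromatic carbon.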